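The source may hold more compounds than are shown below. What is called first, only, known or untested is meant among the compounds shown, and "the series" means these compounds.

Measured so far:
compound 1 `CCCCCc1nc(N)n(CC(=O)Nc2ccc(C)cc2)c1-c1ccccc1Br` — 4300 nM
compound 2 `CCCCCCc1nc(N)n(CC(=O)Nc2ccc(C)cc2)c1-c1ccccc1Br` — 5100 nM

In a functional assay on A-375 cells (Homo sapiens) for antiproliferative activity, read by MTT assay, with a stated time of 48 h (on this read-out higher numbers stand for weaker inhibition and lower numbers for stronger inhibition), compound 1 gives 4300 nM. In this assay compound 2 gives 5100 nM. On the numbers shown, compound 2 and compound 1 sit within the scatter of each other: the step of a 1.2-fold higher number from compound 1 to compound 2 (0.07 log units; within the scatter) is too small to separate them, so compound 2 cannot be called weaker or stronger than compound 1.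

Compound 3 `Cc1ccc(NC(=O)Cn2c(N)nc(CC3CCCC3)c2-c2ccccc2Br)cc1` differs from compound 2 by cyclopentyl in place of pentyl on a saturated chain carbon bound to an aromatic carbon. For the measured compounds named here, the only measured step that bears on this part of the molecule is a 1.2-fold higher number from compound 1 to compound 2 (0.07 log units; within the scatter), which lengthened the chain by one carbon without moving the number beyond the scatter. Going by the values given here, no measured step closes the chain into a ring, so that part of the change has no direct precedent here; what is known is only that this chain tolerated a small change in size without consequence. The expectation is therefore a step of a 1.1-fold lower number from compound 2 to compound 3 (0.05 log units; within the scatter) that stays within the scatter. For compound 3 the estimate is 4500 nM, with a range from 1800 nM to 11000 nM.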

Compound 3, half-maximal inhibitory concentration: 47800 nM
Compound 3: the middle estimate sits 11-fold (1.03 log units) below what was measured, and the stated range ends below it.
By their numbers in this assay, from the lowest: compounds 1 and 2 (each within the scatter of the next); then compound 3.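

In this assay, replacing the open chain with a ring at this place gives a 9.4-fold higher number from compound 2 to compound 3 (0.97 log units; beyond the scatter), and the comparison with the shorter chain gives an 11-fold higher number from compound 1 to compound 3 (1.05 log units; beyond the scatter), so inhibition is clearly weaker with the ring in both comparisons, whereas the one-carbon change in the open chain had stayed within the scatter. Pentyl and cyclopentyl each hold 5 carbon atoms, which shows that at this place two groups with the same carbon count can give very different numbers, and that the tolerance seen between the open chains does not extend to this ring. Nothing available explains why the ring weakens inhibition.

The compounds shown leave open whether the weaker inhibition goes with any ring at this place or only with the five-membered one, a question that a cyclobutyl or cyclohexyl group would help to answer. They also leave open how a chain longer than hexyl, or one carrying an amine or a carboxylic acid, would read in this assay.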